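Pyrazole for thiazole on the fused aryl ring

A few compounds are considered here, and "the series" means these few. Any claim that something is new, unique, unknown or untested is made for them only; others in the source may bear on it.

For the measured compounds named here, compound 1 `c1cc(-c2nccs2)c2c(c1)C(c1ncc[nH]1)CC2` is the only compound with a number in a functional assay on CHO cells for agonist activity at Alpha-1D adrenergic receptor (Homo sapiens), read by FLIPR and calcium flux; a lower number here means that less compound is needed, a higher number that more compound is needed for the effect: compound 1 gives 3190 nM. Compound 2 `Cc1ccc2c(c1NS(C)(=O)=O)CCC2c1ncc[nH]1` reports only a limit in this assay, > 10000 nM, which is the limit of > 10000 nM in this assay, at which 1 of the 2 values shown sits. Compound 3 `Cn1ccc(-c2cccc3c2CCC3c2ncc[nH]2)n1` differs from compound 1 by 1-methyl-1H-pyrazol-3-yl in place of 1,3-thiazol-2-yl on an aromatic carbon. No measured step of this kind exists among the compounds shown, so the expectation rests on compound 1 alone. The exchange is expected to shift this assay little, within or just beyond the scatter, a mild loss being somewhat more likely than a gain. Compound 3 is therefore estimated at 4500 nM, between 1500 nM and 13000 nM. The estimate means an expected step of a 1.4-fold higher number from compound 1 to compound 3 (0.15 log units; within the scatter).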

Compound 3, half-maximal effective concentration: > 10000 nM
Compound 3 was reported as a limit (the forecaster's own chance of this, stated with the estimate: 30%); middle value at least 2.2-fold (0.34 log units) from the limit.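

At this aromatic carbon, ortho to a fused ring, the two five-membered aromatic rings are not interchangeable in this assay: 1-methyl-1H-pyrazol-3-yl in place of 1,3-thiazol-2-yl gives an at least 3.1-fold higher number from compound 1 to compound 3 (0.49 log units; beyond the scatter). Compound 3 reports only a limit, so this step is a minimum and its full size cannot be read. Compound 1 remains the only compound with a number, and further changes can only be read against it: the limit of > 10000 nM in this assay, at which 2 of the 3 values shown sit.

On these data alone, it remains open whether the higher number follows from the methyl group or from the pyrazole ring itself. An unsubstituted pyrazole or a 1,3-oxazol-2-yl group at this carbon would help separate these two readings.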